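A few compounds are considered here, and "the series" means these few. Any claim that something is new, unique, unknown or untested is made for them only; others in the source may bear on it.

The compounds described here were tested in a functional assay on HCT-116 cells (Homo sapiens), read by MTT assay, with a stated time of 72 h; on this read-out lower numbers stand for stronger inhibition and higher numbers for weaker inhibition. Compound 1 `C#Cc1cn([C@@H]2O[C@H](CO)[C@@H](O)[C@H]2O)c2ncnc(C)c12` carries an ethynyl group on the shared core. In this assay compound 1 gives > 20000 nM, which is a limit of the assay rather than a number. Compound 2 `Cc1ncnc2c1c(-c1ccoc1)cn2[C@@H]1O[C@H](CO)[C@@H](O)[C@H]1O` differs from compound 1 by furan-3-yl in place of ethynyl on an aromatic carbon. In this assay compound 2 gives > 20000 nM, again a limit of the assay. The step that the two limits leave unreadable from compound 1 to compound 2 is therefore not readable, because both ends rest on (the limit of > 20000 nM in this assay, at which 3 of the 3 values shown sit).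

Compound 3 `C#Cc1cn([C@@H]2O[C@H](CO)[C@@H](O)[C@H]2O)c2nc(N)nc(OC)c12` has a different core from compound 1; how the two cores differ is not broken down here. In this assay compound 3 gives > 20000 nM, which is a limit of the assay and not a number.

Compound 4 `COc1nc(N)nc2c1c(-c1ccoc1)cn2[C@@H]1O[C@H](CO)[C@@H](O)[C@H]1O` has not yet been measured in this assay. It differs from compound 3 by furan-3-yl in place of ethynyl on an aromatic carbon, the same change that separates compound 1 from compound 2. Since all three measured values sit at the limit of > 20000 nM in this assay, at which 3 of the 3 values shown sit, the measured step offers no direction for this change. The step that the limit leaves unreadable from compound 3 to compound 4 is expected on that basis to be small, because compound 1 and compound 2 both sit at the limit of > 20000 nM in this assay, at which 3 of the 3 values shown sit. Compound 4 is accordingly expected to give about 40000 nM in this assay, with a range from 12000 nM to 150000 nM, most likely reported only as a limit.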

Compound 4, half-maximal inhibitory concentration: > 20000 nM
Compound 4: only a limit was reported; the forecaster's own chance of this, stated with the estimate: 85%; the middle value does not contradict the limit.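

In this assay compound 4 gives > 20000 nM as a limit of the assay and not a number. The change from compound 3 to compound 4 therefore yields no readable step, because both ends rest on a limit: the limit of > 20000 nM in this assay, at which 4 of the 4 values shown sit. The compounds shown leave open whether furan-3-yl in place of ethynyl changes inhibition at all, and what actual number any of these four compounds would give.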